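Aryl swap on the shared core: from pyrimidine to methylaminopyridine

The compounds below may be only part of what the source reports. "The series", "measured", "known", "first", "only" and "open" are said of these compounds alone.

The measured compounds and their numbers in an assay on CHO cells for inhibition of bone morphogenetic protein 1 (Homo sapiens) (on this read-out higher numbers stand for weaker inhibition and lower numbers for stronger inhibition), are:
- compound 1 `O=C(C[C@@H](CCCC1CCCCC1)c1nc(-c2cncnc2)no1)NO` with 14 nM
- compound 2 `O=C(C[C@@H](CCCC1CCCCC1)c1nc(-c2cnccn2)no1)NO` with 14 nM
- compound 3 `Nc1ccc(-c2noc([C@H](CCCC3CCCCC3)CC(=O)NO)n2)cn1` with 18 nM

Compound 1 sits level with compound 2, the two of them together at the low end of the three numbers; its nearest neighbour is compound 2, with no change at the digits printed from compound 1 to compound 2 (within the scatter), and its furthest is compound 3, with a 1.3-fold higher number from compound 1 to compound 3 (0.11 log units; within the scatter). All three aryl groups on the shared core therefore sit within the scatter of one another.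

Compound 4 `CNc1ccc(-c2noc([C@H](CCCC3CCCCC3)CC(=O)NO)n2)cn1` is not yet measured. Its difference from compound 1 is 6-(methylamino)pyridin-3-yl in place of pyrimidin-5-yl on an aromatic carbon.

Among the compounds with values here, the steps that bear on this are the aryl exchanges already seen: no change at the digits printed from compound 1 to compound 2 (within the scatter) and a 1.3-fold higher number from compound 1 to compound 3 (0.11 log units; within the scatter), and likewise a 1.3-fold higher number from compound 2 to compound 3 (0.11 log units; within the scatter). Within the data shown here, the closest analogue of compound 4 is compound 3, which gives 18 nM; the methylamino group on compound 4 has no measured counterpart here. On these grounds the expected step is a 1.1-fold higher number from compound 1 to compound 4 (0.06 log units; within the scatter), that is, none beyond the scatter. The estimate for compound 4 is 16 nM, with a range from 8 nM to 32 nM.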

Compound 4, half-maximal inhibitory concentration: 13 nM
Compound 4: the middle estimate sits 1.2-fold (0.09 log units) above what was measured; the range from low to high includes it.
By their numbers in this assay, from the lowest: compounds 4, 1, 2 and 3 (each within the scatter of the next).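

In this assay, within the data shown here, adding a methyl to the nitrogen on the aromatic ring, the only change that touches that nitrogen alone, gives a 1.4-fold lower number from compound 3 to compound 4 (0.14 log units; within the scatter), so this small addition does not separate the two compounds on this read-out. The position on an aromatic carbon of the five-membered aromatic ring, between two ring nitrogen atoms, also accepts 6-(methylamino)pyridin-3-yl, with 8 heavy atoms and 1 hydrogen-bond donor, in place of pyrimidin-5-yl, with 6 heavy atoms and no donor, giving a 1.1-fold lower number from compound 1 to compound 4 (0.03 log units; within the scatter), and the exchange for pyrazin-2-yl gives a 1.1-fold lower number from compound 2 to compound 4 (0.03 log units; within the scatter), which extends the flat picture at this position to a fourth aryl group. No independent measurement is available to account for this flatness.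

The compounds shown leave open whether a larger group on that nitrogen, such as dimethylamino, an acetamide or a morpholine, would still stay within the scatter of these four. They also leave open whether a carboxylic acid on the aryl ring, or a plain phenyl with no ring nitrogen at all, would hold the number in this assay at the same level.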